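Hydroxymethyl in place of sec-butyl: what to expect of compound 4

A few compounds are considered here, and "the series" means these few. Any claim that something is new, unique, unknown or untested is made for them only; others in the source may bear on it.

In a functional assay on the whole organism (Tail, strain ICR) with Mus musculus as the target, in the tail flick test, with a stated time of 120 min, at a dose of 25 umol/kg by the oral route (a higher number here means a stronger effect of the compound at the dose given, a lower number a weaker effect), the three measured compounds gave these numbers:
compound 1, `O=C(O)[C@@H]1CCCN1C(=O)CN(c1nc(Cl)nc2[nH]cnc12)C1CC1`: 23.6%
compound 2, `N=C(N)NCCC[C@H](NC(=O)CN(c1nc(Cl)nc2[nH]cnc12)C1CC1)C(=O)O`: 17%
compound 3, `CC[C@H](C)[C@H](NC(=O)CN(c1nc(Cl)nc2[nH]cnc12)C1CC1)C(=O)O`: 21.4%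

Compound 3 stands second of the three, but its nearest neighbour is compound 1, a number that lies within the scatter, and its furthest is compound 2, also within the scatter. Compound 4, `O=C(CN(c1nc(Cl)nc2[nH]cnc12)C1CC1)N[C@@H](CO)C(=O)O`, differs from compound 3 by hydroxymethyl in place of sec-butyl on a saturated chain carbon bound to an amide-type nitrogen and a carbonyl carbon. Going by the values given here, the one measured step at this same place, a number 4.4 percentage points higher from compound 2 to compound 3 (within the scatter), stayed within the scatter, although the group that left there was a different one from the sec-butyl that leaves now. Among the compounds with values here, no measured step shows a hydroxymethyl entering at this place. On that basis compound 4 is expected to show no step beyond the scatter, an estimated change of a number 2.4 percentage points lower from compound 3 to compound 4 (within the scatter). Compound 4 is therefore estimated at 19% in this assay, with a range from 8% to 32%.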

Compound 4, a percentage reported as activity, at one dose (the size of the read-out at that dose, not a potency): 39%
Compound 4: middle estimate off by 20 percentage points, on the low side, and the stated range ends below it.
By their numbers in this assay, from the lowest: compounds 2, 3 and 1 (each within the scatter of the next); then compound 4.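

In this assay, the group on the saturated chain carbon bound to an amide-type nitrogen and a carbonyl carbon now gives a step beyond the scatter, with hydroxymethyl in place of sec-butyl (a number 17.6 percentage points higher from compound 3 to compound 4 (beyond the scatter)). Compound 4 also stands clear of the other two compounds, both where one oxygen atom takes the place of the longer nitrogen-bearing group (a number 22 percentage points higher from compound 2 to compound 4 (beyond the scatter)) and where (1-carboxy-2-hydroxyethyl)amino takes the place of 2-carboxypyrrolidin-1-yl (a number 15.4 percentage points higher from compound 1 to compound 4 (beyond the scatter)), making it the most active of the four at this dose. No evidence at hand accounts for this rise.

Going by these compounds, it remains open whether the hydroxyl itself carries the rise, which a methyl or methoxymethyl group at this place could test. Also open, on these data alone, is how a longer chain such as hydroxyethyl, or a methyl ester in place of the carboxylic acid, would read.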